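This account rests on a few compounds, and the source may have more. Where it says the series, first, only, none or still open, it means among the compounds named here.

Compound 1, `Cc1cc(C(=O)O)c(C)n1-c1ccc(C(F)(F)F)c(Cl)c1`, was tested in an assay on cells for inhibition of Palmitoleoyl-protein carboxylesterase NOTUM variant C330S (Homo sapiens), read by fluorescence, with a stated time of 40 min (a higher number here means a weaker inhibitor, a lower number a stronger inhibitor), where compound 1 gives 1500 nM. That is the highest of the two numbers recorded so far. The nearest neighbour is compound 2, `Cc1cc(C(=O)O)c(C)n1-c1cccc(Cl)c1Cl`, which in this assay gives 220 nM, a gap that lies beyond the usual scatter of such measurements. Compound 2 is not a single-point variation of compound 1, so nothing in that pair can be read as the effect of one change.

The compound still to be measured is compound 3, `Cc1cc(C(=O)O)c(C)n1-c1ccc(Cl)c(Cl)c1`. It differs from compound 1 in one place: chloro in place of trifluoromethyl on an aromatic carbon, with the shared core otherwise untouched. Among the compounds with values here, no measured pair shows this exchange, so the size of the step is open. Within the data shown here, the only guide is that compound 2, carrying two chloro groups and no trifluoromethyl, gives 220 nM in this assay, while compound 1 gives 1500 nM; this hints at a move toward a lower number, though the chloro groups sit differently in the two. Compound 3 is therefore expected to give about 600 nM in this assay, within a range from 200 nM to 1800 nM. The estimated step is a 2.5-fold lower number from compound 1 to compound 3 (0.40 log units; beyond the scatter).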

Compound 3, half-maximal inhibitory concentration: 270 nM
Beside the measured number, compound 3's estimate is 2.2-fold (0.35 log units) above it; the range from low to high includes it.
By their numbers in this assay, from the lowest: compounds 2 and 3 (each within the scatter of the next); then compound 1.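

In this assay, within the data shown here, chloro in place of trifluoromethyl on this aromatic carbon, ortho to a chloro group and para to a large group, gives a 5.6-fold lower number from compound 1 to compound 3 (0.74 log units; beyond the scatter), and this is the first pair in the set that isolates a single change. The step lies beyond the usual scatter, so trifluoromethyl is not needed at this place for inhibition, and the exchange for chloro, with fewer heavy atoms, goes with a lower number on the otherwise untouched core. Nothing available explains why the number falls, and the reading rests on this one pair alone.

The compounds shown leave open whether the same exchange would give a step of similar size on another core, or with the other chloro group removed from the shared core. Going by these compounds, they also leave open how a nitrile, a methoxy group, a bromo group or a plain hydrogen at this place would read in this assay, so it remains unknown whether chloro is the best of the groups that could stand here or merely one of several that serve equally well.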